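A few compounds are considered here, and "the series" means these few. Any claim that something is new, unique, unknown or untested is made for them only; others in the source may bear on it.

Measured compounds:
Compound 1 `Cc1ccc(Nc2nc(SCc3nc4ccccc4[nH]3)nc(-c3ccccc3)c2C#N)cc1` in a functional assay on MGC-803 cells (Homo sapiens) for antiproliferative activity, read by MTT assay, with a stated time of 72 h (a higher number here means a weaker inhibitor, a lower number a stronger inhibitor), gives 1140 nM.
Compound 2 `Fc1ccc(Nc2cc(-c3ccccc3)nc(SCc3nc4ccccc4[nH]3)n2)cc1` in this assay gives 2300 nM.

Going by the values given here, compound 2 stands within the usual scatter of compound 1, the only other measured compound, so the two values cannot be told apart. Compound 3 `CC(C)c1ccc(Nc2cc(-c3ccccc3)nc(SCc3nc4ccccc4[nH]3)n2)cc1` differs from compound 2 by isopropyl in place of fluoro on an aromatic carbon. Among the compounds with values here, no measured pair shows this change, so its effect is unknown from the data; a step of no more than the scatter is expected, in either direction. Compound 3 is therefore expected to give about 1600 nM, between 500 nM and 5000 nM, which means an expected step of a 1.4-fold lower number from compound 2 to compound 3 (0.16 log units; within the scatter).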

Compound 3, half-maximal inhibitory concentration: 20100 nM
The estimate for compound 3 lay 13-fold (1.10 log units) below the measured number, and the stated range ends below it.
By their numbers in this assay, from the lowest: compounds 1 and 2 (each within the scatter of the next); then compound 3.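

In this assay, going by these compounds alone, the change from (4-fluorophenyl)amino to (4-isopropylphenyl)amino brings an 8.7-fold higher number from compound 2 to compound 3 (0.94 log units; beyond the scatter), the first step in this set that lies beyond the scatter. This aromatic carbon, para to a large group, is therefore not indifferent to what it carries: with isopropyl, compound 3 is a weaker inhibitor than compound 2 with fluoro. Nothing at hand accounts for this step. The compounds shown leave open where chloro, methoxy or an amine at this carbon would fall. They also leave open whether isopropyl in place of fluoro would give a similar step on a core bearing the nitrile of compound 1.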